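Chromone dithiocarbamate series: dropping the ring chloro

The compounds below may be only part of what the source reports. "The series", "measured", "known", "first", "only" and "open" are said of these compounds alone.

Compound 1, `CCOC(=O)c1cc(=O)c2cc(CSC(=S)N(C(C)C)C(C)C)ccc2o1`. In a functional assay on LM7 cells (Homo sapiens) for antiproliferative activity, read by MTT assay, with a stated time of 72 h (on this read-out higher numbers stand for weaker inhibition and lower numbers for stronger inhibition), compound 1 reports only a limit, > 25000 nM.
Compound 2, `O=c1c(SC(=S)N2CCCCC2)coc2ccccc12`. In this assay compound 2 gives 7800 nM.
Compound 3, `O=c1cc(CSC(=S)N2CCCCC2)oc2cc(Cl)ccc12`. In this assay compound 3 gives 13800 nM.

Going by the values given here, only two actual numbers exist in this assay; the third entry is a limit, (the limit of > 25000 nM in this assay, at which 1 of the 3 values shown sits), which concerns compound 1 alone. Compound 3 and compound 2 sit within the scatter of each other, so the two numbers cannot be told apart and no order between them is claimed. Among the compounds with values here, compound 3 therefore stands in the weak range with the one other numbered compound, and nothing about the series beyond these three is established.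

Compound 4, `O=c1cc(CSC(=S)N2CCCCC2)oc2ccccc12`, has not yet been measured in this assay. It differs from compound 3 in one place: hydrogen in place of chloro on an aromatic carbon. Within the data shown here, no measured pair in the set differs in a single place, so no step of this kind is on record to lean on.

With the chloro removed, the change is small in atom count and the rest of the molecule is kept. The expected step from compound 3 to compound 4 is none beyond the scatter, estimated as a 1.2-fold lower number from compound 3 to compound 4 (0.06 log units; within the scatter) in this assay. Compound 4 is estimated at 12000 nM, with a range from 5000 nM to 30000 nM.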

Compound 4, half-maximal inhibitory concentration: > 25000 nM
Compound 4 was reported as a limit; the forecaster's own chance of this, stated with the estimate: 15%; at least 2.0-fold (0.31 log units) between middle value and limit.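

The pair of compound 3 and compound 4 gives the series its first step in a single place, hydrogen in place of chloro on an aromatic carbon: in this assay this change gives an at least 1.8-fold higher number from compound 3 to compound 4 (0.25 log units; that floor lies within the scatter). Removing the chloro from this aromatic carbon therefore brings no measurable gain in inhibition, but the floor of the step does not by itself establish that the chloro contributes, and the full size of the step cannot be read. The value for compound 4 is a limit and not a number, and the series now has two such entries: the limit of > 25000 nM in this assay, at which 2 of the 4 values shown sit.

Going by these compounds, whether fluoro, bromo, methoxy or a carboxylic acid on the same aromatic carbon would give a number clearly apart from that of compound 3 remains open, as does whether a chloro on another aromatic carbon of the core would behave the same way. Compound 1 and compound 2 differ from this pair in more than one place, so they do not settle whether the chloro would matter with a different side chain.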